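A Single Methyl Step on a Weak Cytotoxic Compound

The source may hold more compounds than are shown below. What is called first, only, known or untested is meant among the compounds shown, and "the series" means these compounds.

Compound 2 `COc1cc2c(Nc3nc4ccc(C(=O)Nc5c(C)cccc5C)cc4s3)ncnc2cc1OCCCN1CCCCC1C` was tested in a functional assay on U-937 cells (Homo sapiens) for cytotoxicity, read by WST assay, with a stated time of 72 h (a lower number here means a stronger inhibitor, a higher number a weaker inhibitor), where compound 2 gives 10800 nM. Compound 1 `COc1cc2c(Nc3nc4ccc(C(=O)Nc5c(C)cc(C)cc5C)cc4s3)ncnc2cc1OCCCN1CCC(C)CC1` gives 5600 nM in this assay. Of these two numbers, compound 2 has the higher one, but its gap to compound 1 lies within the scatter, so the two cannot be ranked. Compound 3 `COc1cc2c(Nc3nc4ccc(C(=O)Nc5c(C)cc(C)cc5C)cc4s3)ncnc2cc1OCCCN1CCCCC1C` has not been measured. It differs from compound 2 by methyl in place of hydrogen on an aromatic carbon. Among the compounds with values here, no measured pair shows this change on its own, so no step beyond the scatter is expected in either direction. The expected step of a 1.4-fold lower number from compound 2 to compound 3 (0.13 log units; within the scatter) is small. Compound 3 is estimated at 8000 nM, within a range of 3000 nM to 20000 nM.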

Compound 3, half-maximal inhibitory concentration: 3600 nM
Beside the measured number, compound 3's estimate is 2.2-fold (0.35 log units) above it, and the stated range covers the measured number.
By their numbers in this assay, from the lowest: compounds 3, 1 and 2 (each within the scatter of the next, the first and the last beyond it).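

In this assay, within the data shown here, going from 2,6-dimethylphenyl to 2,4,6-trimethylphenyl gives a 3.0-fold lower number from compound 2 to compound 3 (0.48 log units; beyond the scatter) and is the first single change here to stand clear of the scatter, so a methyl on this ring carbon, para to the large group, does register. Swapping 4-methylpiperidin-1-yl for 2-methylpiperidin-1-yl gives a 1.6-fold lower number from compound 1 to compound 3 (0.19 log units; within the scatter) and so shows no readable difference. Nothing measured here explains the methyl step.

As far as these compounds go, whether a chlorine atom, a methoxy group or an amine on that ring carbon would move the number stays open. So does whether the methyl step holds with other amines at the end of the chain.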